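A Chain Replaces an Amine on the Shared Core

This account rests on a few compounds, and the source may have more. Where it says the series, first, only, none or still open, it means among the compounds named here.

Compound 1 `COc1cc2ncnc(-n3nc(-c4ccccn4)nc3N)c2cc1N` carries an amino group on its core. In an ADME assay on BJ cells (Homo sapiens) for cytotoxicity, with a stated time of 72 h (a lower number here means that less compound is needed, a higher number that more compound is needed for the effect), compound 1 gives "not determined" (no result reported), so no single number marks where it stands. One further measurement exists, for compound 2 `COc1cc2nc(C)nc(-n3nc(-c4ccccn4)nc3N)c2cc1OC`. In this assay compound 2 gives > 13000 nM, which is a limit of the assay rather than a number. The whole evidence on cytotoxicity therefore rests on (the limit of > 13000 nM in this assay, at which 1 of the 2 values shown sits).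

Compound 3 `COc1cc2ncnc(-n3nc(-c4ccccn4)nc3N)c2cc1OCCCNC(=O)C(F)(F)F` differs from compound 1 by 3-(((trifluoromethyl)carbonyl)amino)propoxy in place of amino on an aromatic carbon. No measured step connects any pair of these compounds, so the size of the change in this assay from compound 1 to compound 3 cannot be read off; the working expectation is a step no larger than the usual scatter, in no particular direction. Compound 3 is expected to give about 15000 nM in this assay, somewhere between 4000 nM and 60000 nM, and quite possibly only as a limit.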

Compound 3, half-maximal effective concentration: > 7000 nM
Compound 3: only a limit was reported (the forecaster's own chance of this, stated with the estimate: 65%); the middle value is on the limit's open side.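

In this assay compound 3 gives > 7000 nM, which is a limit of the assay and not a number. Going by these compounds alone, with no single number for compound 1 either, no step from compound 1 to compound 3 can be read. The compounds shown leave open what concentration of any of them produces the effect.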